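Three Inactive Triazole Phthalimides and a Fourth to Test

The source may hold more compounds than are shown below. What is called first, only, known or untested is meant among the compounds shown, and "the series" means these compounds.

Measured so far:
- compound 1, `CCCc1nnc(SCC(=O)c2ccc(Cl)cc2)n1N1C(=O)c2ccccc2C1=O`: > 200000 nM
- compound 2, `C#CCSc1nnc(CCC)n1N1C(=O)c2ccccc2C1=O`: > 200000 nM
- compound 3, `C#CCSc1nnc(-c2cc(OC)c(OC)c(OC)c2)n1N1C(=O)c2ccccc2C1=O`: > 200000 nM

All three compounds were tested in a functional assay on A549 cells (Homo sapiens) for cytotoxicity, read by MTT assay, with a stated time of 48 h; a lower number here means a stronger inhibitor, a higher number a weaker inhibitor. Each value is a limit of the assay and not a number. Compound 1 reaches only its limit of > 200000 nM. Compound 2 likewise reaches only its limit of > 200000 nM. Compound 3 too gives only its limit of > 200000 nM. The evidence is summed up in the limit of > 200000 nM in this assay, at which 3 of the 3 values shown sit.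

Compound 2 and compound 1 differ by (4-chlorophenyl)carbonyl in place of ethynyl on a saturated chain carbon bound to a sulfur. The step that the two limits leave unreadable from compound 2 to compound 1 cannot be sized, since both ends are limits. Compound 3 and compound 2 share the sulfur-bearing propargyl side chain, but the difference between the two cores is not broken down here.

Compound 4, `COc1cc(-c2nnc(SCC(=O)c3ccc(Cl)cc3)n2N2C(=O)c3ccccc3C2=O)cc(OC)c1OC`, has not yet been measured. It differs from compound 3 by (4-chlorophenyl)carbonyl in place of ethynyl on a saturated chain carbon bound to a sulfur, the same change as from compound 2 to compound 1, at the same place. With every measured compound sitting at the limit, compound 4 is expected to stay near that limit as well, with an estimated step that the limit leaves unreadable from compound 3 to compound 4. Compound 4 is therefore estimated at 300000 nM in this assay, within 100000 nM to 1000000 nM.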

Compound 4, half-maximal inhibitory concentration: 9030 nM
Estimate against measurement, compound 4: 33-fold (1.52 log units) above; the measured number lies below the stated range.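

In this assay, with the 3,4,5-trimethoxyphenyl core, putting (4-chlorophenyl)carbonyl in place of ethynyl gives an at least 22-fold lower number from compound 3 to compound 4 (1.34 log units; beyond the scatter), and with the (4-chlorophenyl)carbonyl side chain held fixed, putting 3,4,5-trimethoxyphenyl in place of propyl gives an at least 22-fold lower number from compound 1 to compound 4 (1.34 log units; beyond the scatter), so a readable number appears only where the two groups stand together. The same change on the core of compound 2 cannot be read, as both of its ends are limits, so this does not show that the change carries from one core to another, nor that it fails to. Each readable step gives only a minimum size, since one of its ends is a limit, and only compound 4 has a measured number: the limit of > 200000 nM in this assay, at which 3 of the 4 values shown sit.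

The compounds shown leave open which part of the entering group matters: the chlorine, the carbonyl or the aromatic ring. Also open, going by these compounds, is how a longer chain in place of propyl, or an amine or a carboxylic acid in place of the 4-chlorophenyl, would read.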